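Series notes: aryl for benzyl on the aromatic nitrogen

The source may hold more compounds than are shown below. What is called first, only, known or untested is meant among the compounds shown, and "the series" means these compounds.

In an assay on HEK-293T cells for antagonist activity at vitamin D3 receptor (Homo sapiens), read by a luciferase reporter, with a stated time of 24 h (a lower number here means a stronger inhibitor, a higher number a weaker inhibitor), compound 2, `CC(C)c1onc(-c2c(Cl)cccc2Cl)c1COc1ccc(-c2nc3ccc(C(=O)O)cc3n2Cc2ccc(F)cc2)cc1`, gives 1140 nM. Within the data shown here, this is the only actual number in the set so far. Compound 1, `CCC(CC)n1c(-c2ccc(OCc3c(-c4c(Cl)cccc4Cl)noc3C(C)C)cc2F)nc2ccc(C(=O)O)cc21`, returns > 10000 nM, which is a limit of the assay rather than a measured number, as recorded in the limit of > 10000 nM in this assay, at which 1 of the 2 values shown sits. Compound 3, `CC(C)c1onc(-c2c(Cl)cccc2Cl)c1COc1ccc(-c2nc3ccc(C(=O)O)cc3n2-c2ccc(F)cc2)cc1`, has not yet been measured in this assay. It differs from compound 2 by 4-fluorophenyl in place of 4-fluorobenzyl on an aromatic nitrogen. Among the measured compounds shown here, no measured step in the set speaks to a change of this kind, so the size of the step is open. A small loss, near the edge of the usual scatter, is expected, a 1.8-fold higher number from compound 2 to compound 3 (0.24 log units; within the scatter). Compound 3 is expected to give 2000 nM in this assay, with a range from 700 nM to 8000 nM.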

Compound 3, half-maximal inhibitory concentration: 2410 nM
Beside the measured number, compound 3's estimate is 1.2-fold (0.08 log units) below it, and the stated range covers the measured number.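

In this assay, the aromatic nitrogen now has its first readable step: 4-fluorophenyl in place of 4-fluorobenzyl gives a 2.1-fold higher number from compound 2 to compound 3 (0.33 log units; beyond the scatter). The group on this nitrogen can therefore be shortened by one carbon at a modest cost, and compound 3 still gives a measured number, 2410 nM. Compound 1 stands at > 10000 nM, which is a limit of the assay and not a number, and it differs from compound 2 in more than one place, so it adds nothing to this step.

Nothing shown bears on why the step has this size. Also open, from the compounds shown here alone, is how a longer chain such as 2-phenylethyl, an amine on that chain, or a phenyl without the fluorine would read at this nitrogen.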